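Hydroxyl for acetamide on the biphenyl side chain

The source may hold more compounds than are shown below. What is called first, only, known or untested is meant among the compounds shown, and "the series" means these compounds.

Measured so far:
compound 1 `CC(=O)NCc1ccccc1-c1ccc(COC2CC[C@H](N3CCCCCC3)[C@H]2OC/C=C\CCC(=O)O)cc1` — 126 nM
compound 2 `O=C(O)CC/C=C\CO[C@H]1[C@@H](OCc2ccc(-c3ccccc3CO)cc2)CC[C@@H]1N1CCCCCC1` — 12.6 nM

In a functional assay for antagonist activity at thromboxane A2 receptor (Rattus norvegicus) (on this read-out lower numbers stand for tighter binding and higher numbers for weaker binding), compound 1 gives the higher of the two numbers recorded; compound 2 gives the lower one, and the gap between them lies beyond the scatter. No counted difference between compound 1 and compound 2 is given, so only the two values themselves are noted.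

Compound 3 `O=C(O)CC/C=C\CO[C@H]1C(OCc2ccc(-c3ccccc3CCO)cc2)CC[C@@H]1N1CCCCCC1` has not yet been measured in this assay. It differs from compound 1 by hydroxymethyl in place of acetamido on a saturated chain carbon bound to an aromatic carbon. Among the measured compounds shown here, the change removes the amide and leaves a hydroxyl on the side chain, a pattern that compound 2 also carries; compound 2 shows the lower number of the pair, and this is the only guide available.

The step from compound 1 to compound 3 is expected to run toward a lower number, beyond the scatter: a 5.0-fold lower number from compound 1 to compound 3 (0.70 log units; beyond the scatter). Compound 3 is accordingly estimated at 25 nM, with a range of 6 nM to 100 nM.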

Compound 3, dissociation constant: 31.6 nM
For compound 3 the middle estimate is 1.3-fold (0.10 log units) below the measured one, within the range that was stated.
By their numbers in this assay, from the lowest: compound 2; then compound 3; then compound 1.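

In this assay, among the compounds shown here, a 4.0-fold lower number from compound 1 to compound 3 (0.60 log units; beyond the scatter) marks the first step that can be read at this place, the saturated chain carbon bound to an aromatic carbon. The number here therefore depends on the group this carbon carries, and 2-(2-hydroxyethyl)phenyl stands lower than 2-(acetamidomethyl)phenyl, with the change in a single place and a modest size. No independent measurement bears on the reason for this step.

For the compounds shown here, the single step cannot separate the removal of the acetamido group from the arrival of the hydroxyl, since both happen together. A methyl ether, a primary amine or a carboxylic acid in place of that hydroxyl would test whether the lower number depends on the hydroxyl itself, and a longer chain would test how far the position tolerates extension.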